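Methoxy in place of fluoro on an aromatic carbon

The source may hold more compounds than are shown below. What is called first, only, known or untested is meant among the compounds shown, and "the series" means these compounds.

Going by the values given here, in a functional assay on A549 cells (Homo sapiens) for inhibition, read by CCK-8 assay, with a stated time of 72 h, tested at 1 uM (on this read-out higher numbers stand for more inhibition of growth at the one concentration tested and lower numbers for less inhibition of growth), compound 1 (`CN(C)C(=O)c1cc2cnc(Nc3ccc(NC(=O)C4(C(=O)Nc5ccc(F)cc5)CC4)cc3)nc2n1C1CCCC1`) gives 86.6% and holds the higher of the two numbers so far. Compound 2 (`Cc1cccc(NC(=O)C2(C(=O)Nc3ccc(Nc4ncc5cc(C(=O)N(C)C)n(C6CCCC6)c5n4)cc3)CC2)c1`), with 3-methylphenyl in place of 4-fluorophenyl on an amide-type nitrogen, gives 35.2% and sits well under it. The gap is large and beyond the scatter: a number 51.4 percentage points lower from compound 1 to compound 2 (beyond the scatter).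

The next compound is compound 3 (`COc1ccc(NC(=O)C2(C(=O)Nc3ccc(Nc4ncc5cc(C(=O)N(C)C)n(C6CCCC6)c5n4)cc3)CC2)cc1`), which has methoxy in place of fluoro on an aromatic carbon, para to a large group: methoxy in place of fluoro on an aromatic carbon. Among the compounds with values here, only one measured step bears on this change. It touches the same 4-fluorophenyl group, and in compound 2 the loss of that group came with a number 51.4 percentage points lower from compound 1 to compound 2 (beyond the scatter). That single step cannot separate losing the fluoro from placing a new group elsewhere on the ring. Compound 3 keeps its group where the fluoro stood, so a fall of smaller size is expected, though with wide uncertainty. The estimated step is expected to be a number 28.6 percentage points lower from compound 1 to compound 3 (beyond the scatter). For compound 3 the estimated value is 58%, with an expected range of 28% to 86%.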

Compound 3, percent growth inhibition at one concentration: 74.4%
Beside the measured number, compound 3's estimate is 16.4 percentage points below it, and the stated range covers the measured number.
By their numbers in this assay, from the lowest: compound 2; then compound 3; then compound 1.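

In this assay, moving from 4-fluorophenyl to 4-methoxyphenyl gives a number 12.2 percentage points lower from compound 1 to compound 3 (beyond the scatter), a modest step, so the fluoro on this aromatic carbon, para to a large group, can give way to methoxy with most of the growth inhibition kept. The large step of a number 39.2 percentage points higher from compound 2 to compound 3 (beyond the scatter) shows that the low number of compound 2 cannot be read as the general price of losing the fluoro, since compound 3 lacks it too and still stands well above compound 2. No measurement on hand explains why methoxy stays close to fluoro here or why 3-methylphenyl falls so far behind.

As far as these compounds go, whether the gap between 3-methylphenyl and 4-methoxyphenyl belongs to the group itself or to where it sits on the ring remains open, for these two compounds change both at once. Also open, from the compounds shown here alone, is how an amine or a carboxylic acid on the same aromatic carbon would read in this assay, and whether any group there could match or pass fluoro.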